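The source may hold more compounds than are shown below. What is called first, only, known or untested is meant among the compounds shown, and "the series" means these compounds.

Measured compounds:
compound 1, `O=c1[nH]c2ccccc2cc1/C=N/c1ccc(O)cc1`, in a functional assay, read by spectrophotometry, with a stated time of 1 h; on this read-out lower numbers stand for stronger inhibition and higher numbers for weaker inhibition: "not active" (no number reported)
compound 2, `NS(=O)(=O)c1ccc(/N=C/c2cc3ccccc3[nH]c2=O)cc1`, in this assay: 266000 nM

Compound 1 stands without a single number in this assay: it is recorded only as "not active" (no number reported), so no half-maximal inhibitory concentration is available for it. Within the data shown here, the one number belongs to compound 2, which in this assay gives 266000 nM, a very weak result. Among the measured compounds shown here, no step between two measured compounds is available, so the two values show only that neither the hydroxyl-bearing compound 1 nor the sulfonamide-bearing compound 2 inhibits to a useful degree.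

Compound 3, `Cc1ccc2[nH]c(=O)c(/C=N/c3ccc(O)cc3)cc2c1`, has not yet been measured in this assay. It differs from compound 1 by methyl in place of hydrogen on an aromatic carbon, the methyl sitting meta to a fused ring and para to a fused ring on the shared core. Given that compound 1 gave "not active" (no number reported), compound 3 is expected to remain very weak as well, with no step beyond the usual scatter. Compound 3 is estimated at 300000 nM, within a range from 80000 nM to 1500000 nM.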

Compound 3, half-maximal inhibitory concentration: "not active" (no number reported)
Compound 3 has no reported number here; no gap can be computed for the estimate.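

In this assay compound 1 gives "not active" (no number reported) and compound 3 gives "not active" (no number reported), so no new step can be read for methyl in place of hydrogen. No supporting evidence bears on this result. The compounds shown leave open whether methyl at this place on the shared core changes inhibition at all.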